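The source may hold more compounds than are shown below. What is called first, only, known or untested is meant among the compounds shown, and "the series" means these compounds.

Series notes. Compound 1 `Cc1cccc(Oc2ccnc(N3CCC[C@H]3C(=O)NCCCn3ccnc3)n2)c1` gives 0% in an assay on isolated protein for inhibition of calcium/calmodulin-dependent protein kinase type II subunit alpha (Homo sapiens), read by HTRF, tested at 10 uM; on this read-out lower numbers stand for less inhibition and higher numbers for more inhibition at the one concentration tested (going by the name of the read-out). Compound 2 `Cc1cccc(N(C)c2cc(Nc3cccc(C(=O)N4CCCC5CCCCC54)c3)ncn2)c1` gives 0% in the same read-out and so stands level with compound 1 at the digits shown, the two values lying within the scatter of each other, with no step between them to report. Compound 3 `Cc1cccc(N(C)c2cc(Nc3cccc(C(=O)N(CC(C)C)CC(C)C)c3)ncn2)c1` is not yet measured; it differs from compound 2 by a group of 9 heavy atoms (8 carbon, 1 nitrogen; no ring) in place of a group of 10 heavy atoms (9 carbon, 1 nitrogen; one six-membered non-aromatic ring of carbon only, one six-membered non-aromatic ring with 1 hetero atom), on a carbonyl carbon. With both measured compounds at the bottom of the scale, the step from compound 2 to compound 3 is expected to be none beyond the scatter, a number 2 percentage points higher from compound 2 to compound 3 (within the scatter). Compound 3 is accordingly estimated at 2%, within a range from -10% to 15%.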

Compound 3, a percentage reported as inhibition, at one concentration (the size of the read-out at that concentration, not a potency): 0%
Beside the measured number, compound 3's estimate is 2 percentage points above it; the measured number falls inside the stated range.
By their numbers in this assay, from the lowest: compounds 1, 2 and 3 (each within the scatter of the next).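

Diisobutylamino on the carbonyl carbon, in place of the group carrying two six-membered non-aromatic rings, gives no change at the digits printed from compound 2 to compound 3 (within the scatter) in this assay and so leaves the read-out at the bottom of the scale. At this position, an open-chain group and a ring-bearing group therefore cannot be told apart at the one concentration tested. No supporting data bear on this result.

On these data alone, whether a morpholine or a piperazine on the same carbonyl carbon would lift the read-out off the bottom of the scale stays open. Changes elsewhere on the shared core also remain open.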